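Carbamate exchange on the anilide ring: working notes

This account rests on a few compounds, and the source may have more. Where it says the series, first, only, none or still open, it means among the compounds named here.

Measured in a functional assay on MDA-MB-231 cells (Homo sapiens) for antiproliferative activity, read by MTT assay, with a stated time of 72 h; on this read-out lower numbers stand for stronger inhibition and higher numbers for weaker inhibition:
- compound 1 `Cc1ccc(NC(=O)CCc2cccc3c2B(O)OC3)cc1`: 1100 nM
- compound 2 `COc1ccc(NC(=O)CCc2cccc3c2B(O)OC3)cc1`: 850 nM

Among the measured compounds shown here, compound 2, at 850 nM, cannot be separated from compound 1, since the single measured step is a 1.3-fold lower number from compound 1 to compound 2 (0.11 log units; within the scatter). The two numbers therefore define one level in this assay, not a ranking.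

The next structure is compound 3 `CC(C)(C)OC(=O)Nc1ccc(NC(=O)CCc2cccc3c2B(O)OC3)cc1`, with (tert-butoxycarbonyl)amino in place of methoxy on an aromatic carbon, para to a large group: (tert-butoxycarbonyl)amino in place of methoxy on an aromatic carbon.

For the measured compounds named here, only one measured step bears on this change, and it concerns the same substituent place. That exchange of methyl for methoxy left the number within the scatter, as a 1.3-fold lower number from compound 1 to compound 2 (0.11 log units; within the scatter) shows. It is weak guidance, as neither measured compound carries anything like the (tert-butoxycarbonyl)amino group, so the data do not fix a direction. A small drift towards a higher number is assumed, with wide margins, and no shift beyond the scatter is expected. The expected step is a 1.4-fold higher number from compound 2 to compound 3 (0.15 log units; within the scatter).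

For compound 3 the estimate is 1200 nM, with an expected range of 350 nM to 4000 nM.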

Compound 3, half-maximal inhibitory concentration: 29000 nM
Compound 3: the middle estimate sits 24-fold (1.38 log units) below what was measured; the whole stated range lies below it.
By their numbers in this assay, from the lowest: compounds 2 and 1 (each within the scatter of the next); then compound 3.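

In this assay this position proves sensitive to what it carries: the (tert-butoxycarbonyl)amino group gives a 34-fold higher number from compound 2 to compound 3 (1.53 log units; beyond the scatter) and a 26-fold higher number from compound 1 to compound 3 (1.42 log units; beyond the scatter) and both steps lie beyond the scatter, while the exchange of methyl for methoxy gave only a 1.3-fold lower number from compound 1 to compound 2 (0.11 log units; within the scatter) and stayed within it. Among the compounds shown here, the single level shared by compound 1 and compound 2 therefore describes those two small substituents and does not extend to every group on this aromatic carbon, so compound 3 stands alone on the weaker side of the series. Nothing among the data on hand bears on the reason for this large step, which stands as an observation only.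

The compounds shown leave open whether the step follows the overall size of the entering group, its carbamate, its tert-butyl end or the hydrogen-bond donor it brings; a free amine, an acetamide or a plain tert-butyl group on this carbon would help separate these. Also open, as far as these compounds go, is whether any group here, such as chlorine or a carboxylic acid, departs from the level of compound 1 and compound 2 towards a lower number.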